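Swapping Chloro for Methyl on the Benzyl Sulfide

The source may hold more compounds than are shown below. What is called first, only, known or untested is meant among the compounds shown, and "the series" means these compounds.

Measured so far, in a functional assay on DU-145 cells (Homo sapiens) for inhibition, read by trypan blue exclusion, with a stated time of 96 h; on this read-out higher numbers stand for weaker inhibition of growth and lower numbers for stronger inhibition of growth:
Compound 1, `COc1ccc(/C=C(/SCc2ccc(Cl)cc2)C(=O)c2ccc(Cl)cc2)cc1`: 10000 nM
Compound 2, `CSc1ccc(/C=C(/SCc2ccc(Cl)cc2)C(=O)c2ccc(Cl)cc2)cc1`: 25000 nM
Compound 3, `Cc1cc(C)cc(/C=C(/SCc2ccc(Cl)cc2)C(=O)c2ccc(Cl)cc2)c1`: 10000 nM

On these numbers compound 2 stands weakest of the three, since the steps of a 2.5-fold higher number from compound 1 to compound 2 (0.40 log units; beyond the scatter) and a 2.5-fold lower number from compound 2 to compound 3 (0.40 log units; beyond the scatter) are both beyond the scatter, while no change at the digits printed from compound 1 to compound 3 (within the scatter). Compound 4, `CSc1ccc(/C=C(/SCc2ccc(C)cc2)C(=O)c2ccc(Cl)cc2)cc1`, keeps everything of compound 2 except one change: methyl in place of chloro on an aromatic carbon. None of the three measured steps touches this part of the molecule; all of them alter the other aryl group, and even those shifts were modest. With nothing directly comparable, the expectation for this assay is a step no larger than those seen, in either direction, most likely within the scatter. Compound 4 is therefore expected to give 20000 nM (range 8000 nM to 60000 nM), which would mean a 1.3-fold lower number from compound 2 to compound 4 (0.10 log units; within the scatter).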

Compound 4, concentration for 50% growth inhibition: 25000 nM
Estimate against measurement, compound 4: 1.3-fold (0.10 log units) below; measured number inside the range.
By their numbers in this assay, from the lowest: compounds 1 and 3 (each within the scatter of the next); then compounds 2 and 4 (each within the scatter of the next).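

Of the steps shown, this is the only one that touches the 4-chlorobenzyl group rather than the other aryl group, and in this assay methyl in place of chloro gives no change at the digits printed from compound 2 to compound 4 (within the scatter). With the 4-(methylsulfanyl)phenyl group kept, this swap therefore leaves the number unmoved. No measured evidence bears on why this is so.

Still open, on these data alone, is whether an amine or a carboxylic acid at this place would move the number. Also open, as far as these compounds go, is whether the same swap would read alike alongside the 4-methoxyphenyl group of compound 1 or the 3,5-dimethylphenyl group of compound 3.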